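The compounds below may be only part of what the source reports. "The series", "measured", "known", "first", "only" and "open" are said of these compounds alone.

Among the compounds with values here, in a functional assay on the whole organism with Rattus norvegicus as the target (on this read-out lower numbers stand for an effect already at smaller amounts and higher numbers for an effect only at larger amounts of compound), compound 2 `CNc1cc(OC)c(C(=O)NC2CCN(Cc3ccccc3)C2)cc1Cl` gives 0.016 mg/kg, the lower of the two actual numbers so far. Compound 3 `CCN1CCC(NC(=O)c2cc(Cl)c(NC)cc2OC)C1` gives 10 mg/kg, the nearest number. Compound 1 `CCNCCNC(=O)c1cc(Cl)c(N)cc1OC` gives > 30 mg/kg, which is a limit of the assay and not a number.

Compound 4 `COc1cc(NC(C)=O)c(Cl)cc1C(=O)NC1CCN(Cc2ccccc2)C1` has acetyl in place of methyl on a nitrogen on an aromatic ring, the difference from compound 2 being (acetyl in place of methyl on a nitrogen on an aromatic ring). Within the data shown here, no measured step touches this nitrogen. Among the measured compounds shown here, the single measured step, a 630-fold higher number from compound 2 to compound 3 (2.80 log units; beyond the scatter), lies elsewhere in the molecule, on a saturated chain carbon bound to an amine nitrogen in a ring. It bears only indirectly, showing that one change can move the number in this assay by a large amount.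

A moderate rise in the number, beyond the scatter but smaller than that measured step, is therefore expected. The expected change is a 19-fold higher number from compound 2 to compound 4 (1.27 log units; beyond the scatter). For compound 4 the estimate is 0.3 mg/kg, with an expected range of 0.04 mg/kg to 3 mg/kg.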

Compound 4, dose for half-maximal effect: 1.8 mg/kg
For compound 4 the middle estimate is 6.0-fold (0.78 log units) below the measured one, and the stated range covers the measured number.
By their numbers in this assay, from the lowest: compound 2; then compound 4; then compound 3. At a limit, above all of these: compound 1.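

In this assay, the first step read at this nitrogen is a 110-fold higher number from compound 2 to compound 4 (2.05 log units; beyond the scatter), so the group on a nitrogen on an aromatic ring is not a neutral choice in this series. Together with a 630-fold higher number from compound 2 to compound 3 (2.80 log units; beyond the scatter), it shows that a single change at either of two separate places in compound 2 gives a step printed as large, with the rest of the molecule held constant. Compound 1 alone sits at a limit rather than a number, and compound 4 does not: the limit of > 30 mg/kg in this assay, at which 1 of the 4 values shown sits.

Going by these compounds, with only acetyl and methyl compared here, it remains open whether a formyl, an ethyl or a longer chain on this nitrogen would stay close to compound 2 or follow compound 4. Also open, on these data alone, is whether acetyl in place of methyl gives a step of similar size when paired with the ethyl-bearing amine ring of compound 3.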